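This account rests on a few compounds, and the source may have more. Where it says the series, first, only, none or still open, it means among the compounds named here.

Among the measured compounds shown here, in a physicochemical assay for solubility (on this read-out higher numbers stand for higher solubility and lower numbers for lower solubility), two compounds have numbers so far. Compound 1 (`O=S(=O)(Nc1ncccn1)c1ccc2c(c1)OCC[C@@H]2c1ccc(C(F)(F)F)cc1-c1ccc(F)nc1`) reads 408000 nM and compound 2 (`CN1CCN(c2cc(C(F)(F)F)ccc2[C@H]2CCOc3cc(S(=O)(=O)Nc4nccs4)ccc32)CC1`) reads 176000 nM and so stands lower of the two, with the gap between them beyond the usual scatter. Compound 3 (`O=C1OCCN1c1cc(C(F)(F)F)ccc1[C@H]1CCOc2cc(S(=O)(=O)Nc3nccs3)ccc21`) differs from compound 2 in one place (2-oxo-1,3-oxazolidin-3-yl in place of 4-methylpiperazin-1-yl on an aromatic carbon), where 2-oxo-1,3-oxazolidin-3-yl stands in place of 4-methylpiperazin-1-yl on an aromatic carbon, ortho to a large group and meta to a trifluoromethyl group. For the measured compounds named here, no measured pair shows this change, so the expectation is a loose one: a modest downward step in this assay, near the edge of the scatter. The expected size is a 1.8-fold lower number from compound 2 to compound 3 (0.25 log units; within the scatter) on this reading. Compound 3 is therefore estimated at 100000 nM with an expected range from 30000 nM to 300000 nM once it is measured.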

Compound 3, solubility: 295000 nM
Compound 3: the middle estimate sits 3.0-fold (0.47 log units) below what was measured; the measured number falls inside the stated range.
By their numbers in this assay, from the lowest: compounds 2, 3 and 1 (each within the scatter of the next, the first and the last beyond it).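

In this assay the exchange of 4-methylpiperazin-1-yl for 2-oxo-1,3-oxazolidin-3-yl on an aromatic carbon gives a 1.7-fold higher number from compound 2 to compound 3 (0.22 log units; within the scatter) and so stays within the scatter. At this place, ortho to a large group and meta to a trifluoromethyl group, a six-membered ring and a five-membered ring with the same counts of hydrogen-bond donors and acceptors are therefore not told apart by this read-out. Nothing measured here accounts for this result.

Going by these compounds, whether a dimethylamino group or a carboxylic acid on the same aromatic carbon would give a step beyond the scatter remains open. Compound 1 differs from compound 2 and compound 3 in more than one place, so it does not settle this question.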